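Methyl-to-hydrogen step on the ether-bearing chain carbon

A few compounds are considered here, and "the series" means these few. Any claim that something is new, unique, unknown or untested is made for them only; others in the source may bear on it.

Compound 1 `CC(O)(Cc1cn(Cc2ccccc2)nn1)c1ccc(S(=O)(=O)c2ccccc2)cc1` and compound 2 `CC(Cc1cn(Cc2ccccc2)nn1)(OCc1cn(Cc2ccccc2)nn1)c1ccc(S(=O)(=O)c2ccccc2)cc1` sit level in a physicochemical assay, read by spectrophotometry; on this read-out lower numbers stand for stronger inhibition and higher numbers for weaker inhibition: compound 1 gives 600 ug/mL and compound 2 gives 600 ug/mL, no change at the digits shown and within the scatter. Among the measured compounds shown here, compound 2 therefore stands exactly where the only other measured member of the series stands. Compound 3 `O=S(=O)(c1ccccc1)c1ccc(C(Cc2cn(Cc3ccccc3)nn2)OCc2cn(Cc3ccccc3)nn2)cc1` differs from compound 2 by hydrogen in place of methyl on a saturated chain carbon bound to an aromatic carbon, an oxygen on a saturated carbon and a saturated chain carbon. For the measured compounds named here, no step between measured compounds exists to calibrate this change; the one comparison at hand, compound 1 against compound 2, shows that a considerably larger alteration left this assay unmoved. The step is expected to be none beyond the scatter, in either direction, so no change at the digits printed from compound 2 to compound 3 (within the scatter) is estimated as essentially flat. Compound 3 is expected to give 600 ug/mL, between 300 ug/mL and 1200 ug/mL.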

Compound 3, half-maximal inhibitory concentration: 500 ug/mL
Compound 3: the middle estimate sits 1.2-fold (0.08 log units) above what was measured; the measured number falls inside the stated range.
By their numbers in this assay, from the lowest: compounds 3, 1 and 2 (each within the scatter of the next).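

In this assay the position gets its first direct reading: hydrogen in place of methyl on a saturated chain carbon bound to an aromatic carbon, an oxygen on a saturated carbon and a saturated chain carbon gives a 1.2-fold lower number from compound 2 to compound 3 (0.08 log units; within the scatter) and so leaves the read-out level. In this pair the methyl is therefore not needed to hold the read-out at this level, and the compound without it stands with the other two members of the series. No measurement is available that would explain this flat result.

On these data alone, whether a larger or differently functionalised group on this carbon, such as an ethyl chain, an amine or a carboxylic acid, would move the read-out beyond the scatter remains open. The step also rests on a single pair in one assay, so it is not known whether the same exchange would stay flat on a different core.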